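Notes on a cyano-to-ester swap in the series

The source may hold more compounds than are shown below. What is called first, only, known or untested is meant among the compounds shown, and "the series" means these compounds.

Measured compounds:
compound 1 `COc1ccc(/C=C(\C#N)C(=O)c2cc(OC)c(OC)c(OC)c2)cc1O` — 4200 nM
compound 2 `COc1ccc(/C=C(\C#N)C(=O)c2cc(OC)c(OC)c(OC)c2)c(F)c1` — > 10000 nM
compound 3 `COc1ccc(/C=C(\C#N)C(=O)c2cc(OC)c(OC)c(OC)c2)cc1Br` — > 10000 nM

Among the measured compounds shown here, in an ADME assay on K562 cells (Homo sapiens) for cytotoxicity, read by MTT assay, with a stated time of 5 days (on this read-out lower numbers stand for stronger inhibition and higher numbers for weaker inhibition), compound 1 gives 4200 nM, the only number in the set. Compound 2 gives > 10000 nM, which is a limit of the assay and not a number. Compound 3 gives > 10000 nM, likewise a limit. The steps from compound 1 read as an at least 2.3-fold higher number from compound 1 to compound 2 (0.37 log units; beyond the scatter) and an at least 2.3-fold higher number from compound 1 to compound 3 (0.37 log units; beyond the scatter), both beyond the scatter, while a step that the two limits leave unreadable from compound 2 to compound 3 cannot be read because both values sit at the limit of > 10000 nM in this assay, at which 2 of the 3 values shown sit. All three measured steps concern the aryl ring on the double-bonded chain carbon; none touches the chain carbon bound to the carbonyl carbon.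

Compound 4 `CCOC(=O)/C(=C\c1ccc(OC)c(O)c1)C(=O)c1cc(OC)c(OC)c(OC)c1` keeps the 3-hydroxy-4-methoxyphenyl and the shared core of compound 1 and differs only by ethoxycarbonyl in place of cyano on a double-bonded chain carbon bound to a carbonyl carbon and a double-bonded chain carbon. For the measured compounds named here, no measured step bears on this position, so no direction can be drawn from the series, and the two limits show only that departures from compound 1 have so far weakened the read-out. Compound 4 is therefore expected to fall somewhat weaker than compound 1, with wide uncertainty, as a 1.9-fold higher number from compound 1 to compound 4 (0.28 log units; within the scatter). For compound 4 the estimate is 8000 nM, within a range of 2500 nM to 30000 nM.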

Compound 4, half-maximal inhibitory concentration: 870 nM
Estimate against measurement, compound 4: 9.2-fold (0.96 log units) above; the measured number lies below the stated range.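

In this assay, among the compounds shown here, the double-bonded chain carbon bound to a carbonyl carbon and a double-bonded chain carbon proves open to change, which the earlier steps on the aryl ring could not show: ethoxycarbonyl in place of cyano gives a 4.8-fold lower number from compound 1 to compound 4 (0.68 log units; beyond the scatter). For the compounds shown here, the cyano group is therefore not required at this position for the read-out, at least with the 3-hydroxy-4-methoxyphenyl kept, and this change is the first departure from compound 1 in the series to lower the number rather than raise it. The aryl-ring changes in compound 2 and compound 3 each end at a limit of the assay and not a number: the limit of > 10000 nM in this assay, at which 2 of the 4 values shown sit.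

The compounds shown leave open whether the lower number belongs to the ester carbonyl or to its ethyl chain, a question that a carboxylic acid, a primary amide or a longer alkyl ester at this position would help to separate. Also open, from the compounds shown here alone, are the cause of the step, on which these data are silent, and whether ethoxycarbonyl has the same effect alongside 2-fluoro-4-methoxyphenyl or 3-bromo-4-methoxyphenyl.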